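This account rests on a few compounds, and the source may have more. Where it says the series, first, only, none or still open, it means among the compounds named here.

Compound 1 `CCC(=O)N(c1ccc(Cl)cc1)C1CCCC1N(C)C`: 3 mg/kg
Compound 2 `CCC(=O)N(c1ccc(OC)cc1)C1CCCCC1N(C)C`: > 50 mg/kg
Compound 3 `CCC(=O)N(c1ccccc1C)C1CCCC1N(C)C`: 7 mg/kg

These doses come from a functional assay on the whole organism for positive allosteric modulation, with Mus musculus as the target; a lower number here means that less compound is needed, a higher number that more compound is needed for the effect. Compound 2 gives > 50 mg/kg, which is a limit of the assay and not a number. Of the two true numbers, compound 3 has the higher at 7 mg/kg, and the gap down to compound 1 at 3 mg/kg lies beyond the scatter.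

Compound 4 `CCC(=O)N(c1ccccc1Cl)C1CCCC1N(C)C` has chloro in place of methyl on an aromatic carbon, ortho to a large group (chloro in place of methyl on an aromatic carbon). Compound 1 also carries a chloro group and gives 3 mg/kg, so a slightly lower dose seems plausible. The expected step of a 1.4-fold lower number from compound 3 to compound 4 (0.15 log units; within the scatter) stays within the scatter. For compound 4 the estimated dose is 5 mg/kg, with an expected range of 2 mg/kg to 14 mg/kg.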

Compound 4, dose for half-maximal effect: 6 mg/kg
Beside the measured number, compound 4's estimate is 1.2-fold (0.08 log units) below it; measured number inside the range.
By their numbers in this assay, from the lowest: compounds 1, 4 and 3 (each within the scatter of the next, the first and the last beyond it). At a limit, above all of these: compound 2.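

In this assay, chloro in place of methyl on an aromatic carbon, ortho to a large group, gives a 1.2-fold lower number from compound 3 to compound 4 (0.07 log units; within the scatter). Among the compounds shown here, this is the first pair here that differs in one place, and at this position the dose does not tell the two groups apart. Nothing measured here bears on the reason for this result. The compounds shown leave open how a trifluoromethyl group or a carboxylic acid on this same carbon would fare. They also leave open what a plain hydrogen there would give.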